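This account rests on a few compounds, and the source may have more. Where it says the series, first, only, none or still open, it means among the compounds named here.

Compound 1 `CC1(C)C2CC1[C@]1(C)OB([C@H](CCCN=C(N)N)NC(=O)c3ccc(-c4ccccc4)c(N)c3)O[C@@H]1C2` gives 4.7 nM in an assay on isolated protein for inhibition of serine protease 1 (Homo sapiens); a lower number here means a stronger inhibitor, a higher number a weaker inhibitor.
Compound 2 `Cc1cc(-c2ccccc2S(=O)(=O)NC(C)(C)C)ccc1C(=O)N[C@@H](CCCN=C(N)N)B1O[C@@H]2CC3CC(C3(C)C)[C@]2(C)O1` gives 0.7 nM in this assay.
Compound 3 `CC(C)(C)OC(=O)Nc1cccc(-c2cccc(C(=O)N[C@@H](CCCN=C(N)N)B3O[C@@H]4CC5CC(C5(C)C)[C@]4(C)O3)c2)c1` gives 35 nM in this assay.

Among these three results compound 1 holds the second highest number. Its nearest neighbour is compound 2, whose number is lower by a margin beyond the usual scatter, while compound 3 lies furthest away, with a number higher by a margin that is also beyond the scatter. Compound 4 `CC1(C)C2CC1[C@]1(C)OB([C@H](CCCN=C(N)N)NC(=O)c3ccc(-c4ccccc4)cc3)O[C@@H]1C2` has not yet been measured. It differs from compound 1 in a single place: hydrogen in place of amino on an aromatic carbon. Among the compounds with values here, no step between measured compounds isolates this change, so the expectation rests on compound 1 alone. A modest weakening is expected, with the step of a 1.9-fold higher number from compound 1 to compound 4 (0.28 log units; within the scatter) in this assay. Compound 4 is therefore estimated at 9 nM, within a range from 3 nM to 30 nM.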

Compound 4, inhibition constant: 33 nM
For compound 4 the middle estimate is 3.7-fold (0.56 log units) below the measured one; the whole stated range lies below it.
By their numbers in this assay, from the lowest: compound 2; then compound 1; then compounds 4 and 3 (each within the scatter of the next).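

Within the data shown here, replacing the amino group on this aromatic carbon, ortho to a phenyl group, with hydrogen gives a 7.0-fold higher number from compound 1 to compound 4 (0.85 log units; beyond the scatter) in this assay and provides the first single-place comparison. It shows that this position is sensitive to the change, although only one heavy atom leaves. Nothing available explains the size of this step.

On these data alone, whether a hydroxyl or a dimethylamino group at this place would keep the number of compound 1 remains open. So does whether a methylene spacer between the ring and the amino group would do so.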